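Methyl on the sulfonamide nitrogen of compound 2

The source may hold more compounds than are shown below. What is called first, only, known or untested is meant among the compounds shown, and "the series" means these compounds.

Of the compounds shown here, two have been measured so far. In a physicochemical assay for solubility, in phosphate buffer, measured as kinetic solubility, at pH 7.4, tested at 250 uM (a lower number here means a less soluble compound, a higher number a more soluble compound), compound 1 (`CCCCCCNc1ccc([N+](=O)[O-])cc1S(N)(=O)=O`) gives 6000 nM, and compound 2 (`CCCCCCNc1ccc(C(=O)O)cc1S(N)(=O)=O`) gives 238000 nM, the higher of the two numbers. For the measured compounds named here, the only measured step is a 40-fold higher number from compound 1 to compound 2 (1.60 log units; beyond the scatter), with carboxy in place of nitro on an aromatic carbon. That step is large and lies beyond the scatter.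

Compound 3 (`CCCCCCNc1ccc(C(=O)O)cc1S(=O)(=O)NC`) keeps the carboxy group of compound 2 and carries a change elsewhere: methyl in place of hydrogen on a sulfonamide nitrogen. Going by the values given here, the one measured step concerns a different place, so its size does not carry over to this change. Among the compounds with values here, no measured pair covers a change on the sulfonamide nitrogen, and this expectation is therefore weakly supported. With the carboxy group retained, the starting point is compound 2 at 238000 nM, and no step beyond the scatter is expected in this assay. The expected step is a 1.3-fold lower number from compound 2 to compound 3 (0.10 log units; within the scatter). For compound 3 the estimated value is 190000 nM, with an expected range of 90000 nM to 250000 nM.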

Compound 3, solubility: 247000 nM
For compound 3 the middle estimate is 1.3-fold (0.11 log units) below the measured one, and the stated range covers the measured number.
By their numbers in this assay, from the lowest: compound 1; then compounds 2 and 3 (each within the scatter of the next).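

The sulfonamide nitrogen now has its first reading in this assay (a 1.0-fold higher number from compound 2 to compound 3 (0.02 log units; within the scatter)), so at this place, with the carboxy group present, methyl and hydrogen cannot be told apart in this read-out. The earlier step (a 40-fold higher number from compound 1 to compound 2 (1.60 log units; beyond the scatter)) concerned only the exchange of nitro for carboxy on an aromatic carbon and gave no reading at this nitrogen, so the series now has a measured step at a second place on the shared core, and it is far smaller than the first. No measurement is at hand that bears on the reason for this result.

For the compounds shown here, the single reading at this nitrogen comes with carboxy on the aromatic carbon, so it remains open whether methyl on the sulfonamide nitrogen would also stay within the scatter in a partner of compound 1 at 6000 nM with nitro kept in place. Going by these compounds, it also remains open whether a larger group on the same nitrogen, such as ethyl, a second methyl or acetyl, would still read within the scatter of compound 2 in this assay.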